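Amine substituent change from compound 3 to compound 4

The compounds below may be only part of what the source reports. "The series", "measured", "known", "first", "only" and "open" are said of these compounds alone.

Three compounds of the series have numbers in an assay for binding affinity to Sigma non-opioid intracellular receptor 1 (Rattus norvegicus); on this read-out lower numbers stand for stronger inhibition and higher numbers for weaker inhibition. Compound 1 `N#Cc1ccc(OCC2CCN(CCCF)CC2)cc1` gives 4.3 nM. Compound 2 `N#Cc1ccccc1CN1CCC(COc2ccc(I)cc2)CC1` gives 10.5 nM. Compound 3 `FCCCN1CCC(COc2c(F)c(F)c(F)c(F)c2F)CC1` gives 1.7 nM, the lowest number of the three; its gap to compound 1 and its larger gap to compound 2 both lie beyond the scatter, so compound 3 is the strongest binder among these three.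

Compound 4 `Fc1cccc(CN2CCC(COc3c(F)c(F)c(F)c(F)c3F)CC2)c1` differs from compound 3 in one place: 3-fluorophenyl in place of 2-fluoroethyl on a saturated chain carbon bound to an amine nitrogen in a ring. Going by the values given here, no pair with numbers shows this change, so nothing measured sets its size. Compound 2, which also carries an aromatic ring on a chain carbon bound to the ring nitrogen but a different aryl ether, gives 10.5 nM and is only a loose pointer. The expected step from compound 3 to compound 4 is small and of uncertain direction, close to the scatter: a 1.8-fold higher number from compound 3 to compound 4 (0.25 log units; within the scatter). For compound 4 the estimated value in this assay is 3 nM, with a range from 0.8 nM to 12 nM.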

Compound 4, inhibition constant in the Sigma non-opioid intracellular receptor 1 assay: 3.3 nM
Estimate against measurement, compound 4: 1.1-fold (0.04 log units) below; measured number inside the range.
By their numbers in the Sigma non-opioid intracellular receptor 1 assay, from the lowest: compounds 3, 4 and 1 (each within the scatter of the next, the first and the last beyond it); then compound 2.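

The first pair differing in one place shows that swapping 3-fluoropropyl for 3-fluorobenzyl on the amine nitrogen of the shared core leaves binding within the scatter: in the Sigma non-opioid intracellular receptor 1 assay the result is a 1.9-fold higher number from compound 3 to compound 4 (0.29 log units; within the scatter). An aromatic ring on the saturated chain carbon bound to the ring nitrogen is therefore compatible with low nanomolar binding, at least with this aryl ether. In a physicochemical assay for lipophilicity (on this read-out higher numbers stand for higher lipophilicity and lower numbers for lower lipophilicity), compound 3 gives 4.11 and compound 4 gives 4.72. The same change does raise lipophilicity in the physicochemical assay: the measured partition coefficient of compound 3, 4.11, and of compound 4, 4.72, a number 0.61 log units higher (beyond the scatter)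

As far as these compounds go, whether the 3-fluorobenzyl group behaves the same way with the aryl ether of compound 1 remains open, as this step rests on a single pair. Also open, from the compounds shown here alone, is how an unsubstituted benzyl, or a longer chain ending in fluorine, would fare at this nitrogen in either read-out.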